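A few compounds are considered here, and "the series" means these few. Any claim that something is new, unique, unknown or untested is made for them only; others in the source may bear on it.

Compound 1, with the structure `CNC(=O)c1cc(Oc2ccc3nc(Nc4cccc(C(C)(C)C)c4)ncc3c2)ccn1`, was measured in an ADME assay on Caco-2 cells (Homo sapiens) for permeability, in the apical to basolateral direction; a higher number here means that the compound crosses the layer faster, a lower number that the compound crosses the layer more slowly; in this assay compound 1 gives < 1 10^-6 cm/s, which is a limit of the assay rather than a number. Compound 2, `CNC(=O)c1cc(Oc2ccc3nc(Nc4cccc(C(C)(C)C)c4)ccc3c2)ccn1`, gives < 1 10^-6 cm/s, also a limit. Compound 3, `CNC(=O)c1cc(Oc2ccc3nc(Nc4cccc(C(C)(C)C)c4)cnc3c2)ccn1`, gives < 1 10^-6 cm/s, again a limit. All three sit at the same point, as the limit of < 1 10^-6 cm/s in this assay, at which 3 of the 3 values shown sit, records, so compound 1 stands no higher and no lower than the others on the numbers shown. Compound 4, `CCc1ccccc1Nc1ncc2cc(Oc3ccnc(C(=O)NC)c3)ccc2n1`, has not been measured; it differs from compound 1 by 2-ethylphenyl in place of 3-(tert-butyl)phenyl on a nitrogen on an aromatic ring. No step beyond the scatter is expected for this change, and the step of a number no lower from compound 1 to compound 4 (the limit leaves the size open) is the estimate. Compound 4 is therefore expected to give about 1 10^-6 cm/s, within a range from 0.3 10^-6 cm/s to 3 10^-6 cm/s.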

Compound 4, apparent permeability: < 1 10^-6 cm/s
Compound 4 gave a limit, no number; the forecaster's own chance of this, stated with the estimate: 55%; the middle value sits exactly at the limit.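

Compound 4, like compound 1, gives a limit and not a number, so no step can be read between compound 1 and compound 4: the limit of < 1 10^-6 cm/s in this assay, at which 4 of the 4 values shown sit. The compounds shown leave open how the four compare with one another in crossing the layer.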